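A Smaller Group on the Same Core

A few compounds are considered here, and "the series" means these few. Any claim that something is new, unique, unknown or untested is made for them only; others in the source may bear on it.

For the measured compounds named here, in a functional assay on A2780 cells (Homo sapiens) for inhibition (on this read-out lower numbers stand for stronger inhibition and higher numbers for weaker inhibition), compound 3 `CCNC(=O)c1noc(-c2cc(C(C)C)c(O)cc2O)c1-c1cc(CN2CCCC2)no1` gives 55 nM, and this is the only number available for the series. Compound 1 `CCNC(=O)c1noc(-c2cc(C(C)C)c(O)cc2O)c1-c1cc(CNC)no1` has the entry "not determined" (no result reported), and compound 2 `CCNC(=O)c1noc(-c2cc(C(C)C)c(O)cc2O)c1-c1cc(CNC(C)=O)no1` has the entry "not determined" (no result reported). Going by the values given here, neither can serve as a comparison, so no measured step between close relatives shows how much this part of the molecule matters.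

Compound 4 `CCNC(=O)c1noc(-c2cc(C(C)C)c(O)cc2O)c1-c1cc(C(N)=O)no1` keeps the shared core of compound 3 and changes one group: carbamoyl in place of (pyrrolidin-1-yl)methyl on an aromatic carbon. That carbon belongs to a five-membered aromatic ring with 1 nitrogen and 1 oxygen. The change counts out as follows: carbamoyl in place of (pyrrolidin-1-yl)methyl on an aromatic carbon.

With only the value of compound 3 at 55 nM to lean on, any forecast in this assay is loose. The expectation is a modest step towards weaker inhibition, not far beyond the usual scatter of repeat measurements, and the direction itself is uncertain. The expected change is a 2.0-fold higher number from compound 3 to compound 4 (0.30 log units; within the scatter). Compound 4 is expected at about 110 nM, with an estimated range of 30 nM to 400 nM.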

Compound 4, half-maximal inhibitory concentration: 15 nM
Compound 4: middle estimate off by 7.3-fold (0.87 log units), on the high side; the whole stated range lies above it.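

In this assay, putting carbamoyl in place of (pyrrolidin-1-yl)methyl gives a 3.7-fold lower number from compound 3 to compound 4 (0.56 log units; beyond the scatter), a step beyond the usual scatter. For the compounds shown here, this is the first sign that the group on this carbon of the five-membered aromatic ring affects the read-out, something a series with a single number could not show. The ring-bearing group of 6 heavy atoms is also not required for inhibition at this level, since carbamoyl, with 3 heavy atoms, no ring and 1 hydrogen-bond donor, gives the lower number of the pair, although no measurement shown here explains the difference.

A single step cannot tell whether the gain comes from the carbamoyl group itself or simply from the loss of the (pyrrolidin-1-yl)methyl group. A carboxylic acid, a nitrile or a plain aminomethyl group on the same carbon would be useful comparisons for separating these two readings.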